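Chlorine-for-Fluorine Benzyl Swap on a Weak Dithiocarbamate

The compounds below may be only part of what the source reports. "The series", "measured", "known", "first", "only" and "open" are said of these compounds alone.

Compound 1 `O=C1/C(=C/c2ccccc2F)CN(Cc2cn(Cc3cccc(Cl)c3)nn2)C/C1=C\c1ccccc1F` gives 6800 nM. Compound 3 `O=C1/C(=C/c2ccccc2F)CN(Cc2cn(Cc3ccc(F)cc3)nn2)C/C1=C\c1ccccc1F` gives 19400 nM. Compound 2 `O=C1/C(=C/c2ccccc2F)CN(C(=S)SCc2cn(Cc3ccc(F)cc3)nn2)C/C1=C\c1ccccc1F` gives only a limit, > 80000 nM.

These values come from a functional assay on PC-3 cells (Homo sapiens) for cytotoxicity, read by MTT assay, with a stated time of 24 h; a lower number here means a stronger inhibitor, a higher number a weaker inhibitor. Compound 1 and compound 3 differ in one place: 3-chlorophenyl in place of 4-fluorophenyl on a saturated chain carbon bound to an aromatic nitrogen. That change made a step of a 2.9-fold lower number from compound 3 to compound 1 (0.46 log units; beyond the scatter). Compound 2 and compound 3 differ in more than one place, and the difference between the two cores is not broken down here. Compound 4 `O=C1/C(=C/c2ccccc2F)CN(C(=S)SCc2cn(Cc3cccc(Cl)c3)nn2)C/C1=C\c1ccccc1F` is not yet measured; it stands to compound 2 as compound 1 stands to compound 3, the same change: 3-chlorophenyl in place of 4-fluorophenyl on a saturated chain carbon bound to an aromatic nitrogen. The step from compound 2 to compound 4 is expected to be an at least 1.3-fold lower number from compound 2 to compound 4 (0.12 log units; that floor lies within the scatter), a guess that rests on a 2.9-fold lower number from compound 3 to compound 1 (0.46 log units; beyond the scatter) and on (the limit of > 80000 nM in this assay, at which 1 of the 3 values shown sits), since the starting value is only a limit. Compound 4 is therefore expected near 60000 nM, between 20000 nM and 200000 nM.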

Compound 4, half-maximal inhibitory concentration: 80000 nM
For compound 4 the middle estimate is 1.3-fold (0.12 log units) below the measured one, within the range that was stated.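

Set side by side in this assay, the change to 3-chlorophenyl in place of 4-fluorophenyl compares as follows: the same change on two cores in this assay, a 2.9-fold lower number (0.46 log units; beyond the scatter) from compound 3 to compound 1 and a number no higher (the limit leaves the size open) from compound 2 to compound 4; the limit leaves it open whether they differ. On the second core the same change gives a number no higher from compound 2 to compound 4 (the limit leaves the size open). Compound 2 gives only a limit, > 80000 nM, so the size of the step on its core cannot be read. The number did not rise on either core, but this does not show whether the change carries over from one core to the other with the same size.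

The compounds shown leave open how either core responds to a plain benzyl group in place of 4-fluorobenzyl or 3-chlorobenzyl. Going by these compounds, it also remains open what an amine or a carboxylic acid on that phenyl ring would give.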